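This account rests on a few compounds, and the source may have more. Where it says the series, first, only, none or still open, it means among the compounds named here.

Of the compounds shown here, three have so far been measured in a functional assay on the whole organism for inhibition, with Rattus norvegicus as the target, with a stated time of 30 min, at a dose of 1 mg/kg by the intravenous route; on this read-out higher numbers stand for more inhibition at the one dose given (going by the name of the read-out) and lower numbers for less inhibition. Compound 1 `CN1CCN(C(=O)/C=C/c2coc3ccccc3c2=O)CC1` gives 0%. Compound 2 `O=C(Nc1nnn[nH]1)c1cc(=O)c2ccccc2o1` gives 100%. Compound 3 `Cc1c(C(=O)Nc2nnn[nH]2)oc2ccccc2c1=O` gives 70%. On these numbers compound 3 stands second highest of the three: its nearest neighbour is compound 2, which lies higher by a step beyond the scatter, and the furthest is compound 1, which lies lower by a step beyond the scatter. Going by the values given here, the one step between measured compounds that differ in a single place is a number 30 percentage points lower from compound 2 to compound 3 (beyond the scatter), a modest drop that came with methyl in place of hydrogen on an aromatic carbon.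

Compound 4 `O=C(Nc1nnn[nH]1)c1oc2ccccc2c(=O)c1Cl` differs from compound 3 in one place: chloro in place of methyl on an aromatic carbon. Among the compounds with values here, no measured pair exchanges chloro for methyl, so no step bears directly on this change. Within the data shown here, the only step that touches the same position shows that putting a group there in place of hydrogen lowered inhibition, but nothing measured shows how one such group compares with another. The account therefore expects a step of a number 5 percentage points lower from compound 3 to compound 4 (within the scatter) for compound 4, which amounts to no change beyond the scatter. The estimate for compound 4 is 65%, with a range from 35% to 95%.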

Compound 4, a percentage reported as inhibition, in the whole organism at one dose (the size of the read-out at that dose, not a potency): 75%
Estimate against measurement, compound 4: 10 percentage points below, within the range that was stated.
By their numbers in this assay, from the lowest: compound 1; then compounds 3 and 4 (each within the scatter of the next); then compound 2.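

In this assay, going by these compounds alone, chloro in place of methyl on this aromatic carbon gives a number 5 percentage points higher from compound 3 to compound 4 (within the scatter) and so leaves the two groups indistinguishable at this place, a comparison the earlier compounds could not offer. Chloro in place of hydrogen on the same carbon gives a number 25 percentage points lower from compound 2 to compound 4 (beyond the scatter) in the same direction as the earlier a number 30 percentage points lower from compound 2 to compound 3 (beyond the scatter) and also beyond the scatter, so the lower number is no longer tied to methyl alone: with two different groups, both compound 3 and compound 4 lie under compound 2, and neither goes against this within the three compounds that differ at this carbon. Nothing measured on these compounds gives a reason for this drop or for the lack of a difference between methyl and chloro.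

The compounds shown leave open how fluoro, a methoxy group, an amine or a longer chain such as ethyl on this carbon would compare with hydrogen, methyl and chloro in this assay. They also leave open whether the same drop would appear if a carboxylic acid replaced the group of 8 heavy atoms that stands ortho to this position.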